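The source may report more compounds than this note shows. Statements on the series, on what has been measured and on what is new or still open speak of the compounds shown alone.

Compound 1 `C/N=C(\S)CCn1nc(-c2ccccc2)ccc1=O`: 68.2% in a functional assay on the whole organism (stomach) for inhibition, with Rattus norvegicus as the target, at a dose of 100 mg/kg by the intraduodenal route; a lower number here means less inhibition, a higher number more inhibition at the dose given (going by the name of the read-out)
Compound 2 `CC/N=C(\S)CCn1nc(-c2ccccc2)ccc1=O`: 50.3%
Compound 3 `N=C(S)Cn1nc(-c2ccccc2)ccc1=O`: 5.5%

Compound 3 stands lowest of the three numbers in this assay; its nearest neighbour is compound 2, and compound 1 lies furthest from it. Compound 4 `O=C(O)CCn1nc(-c2ccccc2)ccc1=O` differs from compound 3 by a group of 4 heavy atoms (2 carbon, 2 oxygen; no ring) in place of a group of 3 heavy atoms (1 carbon, 1 nitrogen, 1 sulfur; no ring), on a saturated chain carbon bound to an aromatic nitrogen. Among the measured compounds shown here, the steps that bear on this place are a number 62.7 percentage points lower from compound 1 to compound 3 (beyond the scatter) and a number 44.8 percentage points lower from compound 2 to compound 3 (beyond the scatter), both large falls on reaching compound 3. For the measured compounds named here, no measured step shows a carboxymethyl at this place, so the direction is uncertain; with compound 3 already near the floor, only a small to modest change is expected, a number 9.5 percentage points higher from compound 3 to compound 4 (within the scatter). Compound 4 is therefore estimated at 15%, in a range from 0% to 45%.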

Compound 4, a percentage reported as inhibition, in the whole organism at one dose (the size of the read-out at that dose, not a potency): 26.1%
For compound 4 the middle estimate is 11.1 percentage points below the measured one; low and high end bracket the measured number.
By their numbers in this assay, from the lowest: compound 3; then compound 4; then compound 2; then compound 1.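

In this assay, carboxymethyl at this place, on a saturated chain carbon bound to an aromatic nitrogen, gives a number 20.6 percentage points higher from compound 3 to compound 4 (beyond the scatter), so a group without sulfur or nitrogen still retains measurable inhibition. It does not match the groups bearing sulfur and nitrogen, however, with a number 24.2 percentage points lower from compound 2 to compound 4 (beyond the scatter) and a number 42.1 percentage points lower from compound 1 to compound 4 (beyond the scatter). No measurement available here explains these differences.

The compounds shown leave open whether a primary amide, a methyl ester or an amine on the same chain would retain inhibition. They also leave open how a longer chain ending in the carboxylic acid would compare.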